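Sulfonamide substitution in a urea series of enzyme activators

A few compounds are considered here, and "the series" means these few. Any claim that something is new, unique, unknown or untested is made for them only; others in the source may bear on it.

Measured compounds:
compound 1 `CN(Cc1ccccc1)S(=O)(=O)c1ccc(NC(=O)NCc2ccncc2)cc1` — 23 nM
compound 2 `O=C(NCc1ccncc1)Nc1ccc(S(=O)(=O)c2cccc(Cl)c2)cc1` — 69 nM
compound 3 `NS(=O)(=O)c1ccc(NC(=O)NCc2ccncc2)cc1` — 14300 nM

In an assay on isolated protein for activation of Nicotinamide phosphoribosyltransferase (Homo sapiens) (a higher number here means that more compound is needed for the effect, a lower number that less compound is needed), compound 3 stands at the highest number of the three. The steps that lead to it are both large: a 620-fold higher number from compound 1 to compound 3 (2.79 log units; beyond the scatter) and a 210-fold higher number from compound 2 to compound 3 (2.32 log units; beyond the scatter), so the unsubstituted sulfonamide is far weaker than either of its substituted neighbours, which differ from each other only modestly, a 3.0-fold higher number from compound 1 to compound 2 (0.48 log units; beyond the scatter).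

Compound 4 `CCN(CC)S(=O)(=O)c1ccc(NC(=O)NCc2ccncc2)cc1` is the next step from compound 3: diethylamino in place of amino on a sulfonyl sulfur. For the measured compounds named here, no measured compound carries a diethylamino group on the sulfonyl sulfur, so the nearest guide is the reverse of the step from compound 1 to compound 3, where a substituted nitrogen on the sulfonyl sulfur went with a far lower number. Diethylamino carries two small chains rather than a benzyl and a methyl, so the whole of that gain is not taken for granted, but a large step back down is expected, a 57-fold lower number from compound 3 to compound 4 (1.76 log units; beyond the scatter). The estimate for compound 4 in this assay is 250 nM, with a range from 40 nM to 1500 nM.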

Compound 4, half-maximal effective concentration: 384 nM
Estimate against measurement, compound 4: 1.5-fold (0.19 log units) below, within the range that was stated.
By their numbers in this assay, from the lowest: compound 1; then compound 2; then compound 4; then compound 3.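

In this assay, diethylamino brings a large gain over the amino group on the sulfonyl sulfur, a 37-fold lower number from compound 3 to compound 4 (1.57 log units; beyond the scatter), which shows that a substituted nitrogen at this place can lower the number without any ring in the substituent. The gain is only partial, however, a 17-fold higher number from compound 1 to compound 4 (1.22 log units; beyond the scatter) and a 5.6-fold higher number from compound 2 to compound 4 (0.75 log units; beyond the scatter), so among these four compounds the two groups that carry a ring, benzyl(methyl)amino and 3-chlorophenyl, stand lower than the ring-free diethylamino, with amino highest of all. No experimental information at hand accounts for this order.

The compounds shown leave open whether a single ethyl group on the nitrogen, which would keep one amide-type hydrogen, already gives part of the gain, or whether both chains are needed. They also leave open whether longer chains such as dipropylamino, or a piperidine ring closing the two chains on the nitrogen, would bring the number nearer to that of compound 1.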